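This account rests on a few compounds, and the source may have more. Where it says the series, first, only, none or still open, it means among the compounds named here.

- Compound 1 `Nc1n[nH]c2cccc(C#Cc3cccc(C(=O)Nc4cccc(C(F)(F)F)c4)c3)c12`: 15300 nM
- Compound 2 `Nc1n[nH]c2cccc(C#Cc3cccc(C(=O)Nc4cc(C(F)(F)F)cc(C(F)(F)F)c4)c3)c12`: > 100000 nM

For the measured compounds named here, in an ADME assay on L132 cells (Homo sapiens) for inhibition, read by MTT assay, with a stated time of 72 h (on this read-out higher numbers stand for weaker inhibition of growth and lower numbers for stronger inhibition of growth), compound 1 gives 15300 nM and holds the only actual number so far. Compound 2 reads > 100000 nM and this is a limit of the assay, not a number.

Compound 3 `Nc1n[nH]c2cccc(C#Cc3cccc(C(=O)Nc4ccc(Cl)c(C(F)(F)F)c4)c3)c12` is still unmeasured. Its difference from compound 1 is chloro in place of hydrogen on an aromatic carbon, ortho to a trifluoromethyl group.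

Going by the values given here, one measured step bears on this, since it too replaces hydrogen on an aromatic carbon, there with trifluoromethyl: an at least 6.5-fold higher number from compound 1 to compound 2 (0.81 log units; beyond the scatter). A single step is thin ground, so a shift in the same direction is expected, toward weaker growth inhibition, but a smaller one. The expected step is a 1.8-fold higher number from compound 1 to compound 3 (0.26 log units; within the scatter) in this assay as an estimate. For compound 3 the estimated value is 28000 nM, with an expected range from 9000 nM to 90000 nM.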

Compound 3, concentration for 50% growth inhibition: > 100000 nM
Compound 3: a limit, no number; the forecaster's own chance of this, stated with the estimate: 20%; middle value at least 3.5-fold (0.55 log units) away from the limit.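

In this assay, the step shows that chloro at this place, ortho to a trifluoromethyl group and para to a large group, is enough to weaken growth inhibition beyond the scatter: an at least 6.5-fold higher number from compound 1 to compound 3 (0.81 log units; beyond the scatter). Until now, only the addition of a second trifluoromethyl group had been seen to do this, whereas here the entering group is a single chlorine atom. The reading for compound 3 is a limit, so the step gives only a minimum size and cannot be ranked against the trifluoromethyl step: the limit of > 100000 nM in this assay, at which 2 of the 3 values shown sit.

The compounds shown leave open whether any group at this carbon keeps the reading measurable, or whether the effect is special to chloro. A methyl group, a methoxy group or an amine here would help to separate these two possibilities.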